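Dropping the Linker Carbon: Expected Solubility of Compound 4

The source may hold more compounds than are shown below. What is called first, only, known or untested is meant among the compounds shown, and "the series" means these compounds.

For the measured compounds named here, compound 3 `COc1cccc(CNCCCNc2ccnc3cc(Cc4cccc(C(F)(F)F)c4)ccc23)c1O` is one of three compounds measured in a physicochemical assay for solubility, with a stated time of 18 h, at pH 7.4; a higher number here means a more soluble compound, a lower number a less soluble compound. In this assay compound 3 gives 4200 nM. Compound 2 `COc1cccc(CNCCCNc2ccnc3cc(CCC(C)C)ccc23)c1O` gives 4200 nM, and compound 1 `COc1cccc(CNCCCNc2ccnc3cc(Oc4ccccc4)ccc23)c1O` gives 14500 nM. So compound 3 stands level with compound 2 at the digits reported, the two together at the low end of the set, while compound 1 sits higher: a 3.5-fold lower number from compound 1 to compound 3 (0.54 log units; beyond the scatter), and likewise a 3.5-fold lower number from compound 1 to compound 2 (0.54 log units; beyond the scatter).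

Compound 4 `COc1cccc(CNCCCNc2ccnc3cc(-c4ccc(C(F)(F)F)cc4)ccc23)c1O` differs from compound 3 in one place: 4-(trifluoromethyl)phenyl in place of 3-(trifluoromethyl)benzyl on an aromatic carbon.

The measured steps bear on this only loosely. The step of no change at the digits printed from compound 2 to compound 3 (within the scatter) shows that exchanging one group for another on the saturated chain carbon left the number unchanged, and the step of a 3.5-fold lower number from compound 1 to compound 3 (0.54 log units; beyond the scatter) shows a modest fall when a phenoxy group was replaced by a benzyl group. Going by the values given here, no measured step removes the chain carbon between the ring and the core, as this change does. A small step, if any, is therefore expected.

Compound 4 is estimated at 3500 nM in this assay, with a range from 1200 nM to 10000 nM. That estimate corresponds to an expected step of a 1.2-fold lower number from compound 3 to compound 4 (0.08 log units; within the scatter), within the scatter.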

Compound 4, solubility: 32000 nM
Compound 4: middle estimate off by 9.1-fold (0.96 log units), on the low side, and the stated range ends below it.
By their numbers in this assay, from the lowest: compounds 2 and 3 (each within the scatter of the next); then compound 1; then compound 4.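

Until now, every change at this aromatic carbon of the shared core had led downward from compound 1 in this assay, but the new group shows that the number at this position can also rise well above that of compound 1. Exchanging the 3-(trifluoromethyl)benzyl group for 4-(trifluoromethyl)phenyl gives a 7.6-fold higher number from compound 3 to compound 4 (0.88 log units; beyond the scatter) and the same group, set against the isopentyl group, gives a 7.6-fold higher number from compound 2 to compound 4 (0.88 log units; beyond the scatter) even though the group that leaves has just one heavy atom more, and the comparison with the phenoxy group gives a 2.2-fold higher number from compound 1 to compound 4 (0.34 log units; beyond the scatter) and leaves compound 4 with the highest number of the four, clear of the scatter against each of the others. Nothing shown here accounts for this rise.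

The step from compound 3 to compound 4 removes the chain carbon and moves the trifluoromethyl group in a single change, so the compounds shown cannot separate the two, and 3-(trifluoromethyl)phenyl would be the group to tell them apart. Also open, going by these compounds, is how the number would respond to an amine or a carboxylic acid on that same phenyl ring.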